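Chloro for Fluoro: From Compound 3 to Compound 4

The compounds below may be only part of what the source reports. "The series", "measured", "known", "first", "only" and "open" are said of these compounds alone.

Three compounds share one core and differ only in the aromatic group on a carbon with a double bond to nitrogen. In a functional assay on MKN-45 cells (Homo sapiens) for cytotoxicity, read by MTT assay, with a stated time of 72 h (on this read-out lower numbers stand for stronger inhibition and higher numbers for weaker inhibition), compound 1 `CN(C)CCn1cnnc1-c1cc(Oc2ccc(NC(=O)N/N=C/c3cc(C(C)(C)C)cc(C(C)(C)C)c3O)cc2F)ccn1` gives 3300 nM, compound 2 `COc1ccc(/C=N/NC(=O)Nc2ccc(Oc3ccnc(-c4nncn4CCN(C)C)c3)c(F)c2)c(OC)c1OC` gives 2020 nM, and compound 3 `CN(C)CCn1cnnc1-c1cc(Oc2ccc(NC(=O)N/N=C/c3ccc(F)cc3F)cc2F)ccn1` gives 810 nM. Compound 3 thus stands lowest of the three numbers; the nearest is that of compound 2 and the furthest that of compound 1, both beyond the scatter. Within the data shown here, the only step between neighbours is a 2.5-fold lower number from compound 2 to compound 3 (0.40 log units; beyond the scatter), which put 2,4-difluorophenyl in place of 2,3,4-trimethoxyphenyl.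

Compound 4 `CN(C)CCn1cnnc1-c1cc(Oc2ccc(NC(=O)N/N=C/c3ccc(F)cc3Cl)cc2F)ccn1` follows from compound 3 by a far smaller change: chloro in place of fluoro on an aromatic carbon. The same difference, cut one bond further out, reads 2,4-difluorophenyl to 2-chloro-4-fluorophenyl. Among the measured compounds shown here, no measured step exchanges one halogen for another; the step from compound 2 to compound 3 is the only one on this part of the molecule and it replaced the whole group. There is nothing here to foretell a move in either direction, so a step within the scatter is expected in this assay.

Compound 4 is therefore estimated to give 700 nM, with a range from 300 nM to 1600 nM. The expected step is a 1.2-fold lower number from compound 3 to compound 4 (0.06 log units; within the scatter), within the usual scatter.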

Compound 4, half-maximal inhibitory concentration: 870 nM
Compound 4: the middle estimate sits 1.2-fold (0.09 log units) below what was measured; the range from low to high includes it.
By their numbers in this assay, from the lowest: compounds 3 and 4 (each within the scatter of the next); then compounds 2 and 1 (each within the scatter of the next).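

In this assay, among these compounds, the step of a 1.1-fold higher number from compound 3 to compound 4 (0.03 log units; within the scatter) is the first exchange of one halogen for another on this aromatic carbon, ortho to a large group, and it leaves compound 3 and compound 4 within the scatter of each other, so this assay does not separate chloro from fluoro at this place. The step of a 2.3-fold lower number from compound 2 to compound 4 (0.37 log units; beyond the scatter) shows that the lower number seen on leaving 2,3,4-trimethoxyphenyl is not confined to 2,4-difluorophenyl, as 2-chloro-4-fluorophenyl also stands beyond the scatter from that group. Nothing available bears on why the two halogens read alike here.

The compounds shown do not tell whether a bromo group, a methyl group or an amine on this same aromatic carbon would also stay within the scatter of compound 3 and compound 4, or whether the tolerance seen here extends beyond the halogens compared. They also leave open how the number would respond if the fluoro group meta to this place were replaced by a hydrogen or a chloro group.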